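Compound 3 to compound 4: trifluoromethyl for methoxy

The source may hold more compounds than are shown below. What is called first, only, known or untested is meant among the compounds shown, and "the series" means these compounds.

In a functional assay on WiDr cells (Homo sapiens) for inhibition, read by sulforhodamine B assay, with a stated time of 48 h (a higher number here means a weaker inhibitor of growth, a lower number a stronger inhibitor of growth), compound 1 `CCOC(=[Se])Nc1ccc2c(C)cc(=O)oc2c1` gives > 100000 nM, which is a limit of the assay and not a number. Compound 2 `CCCCNC(=[Se])Nc1ccc2c(C)cc(=O)oc2c1` gives 3800 nM. Butylamino in place of ethoxy accounts for an at least 26-fold lower number from compound 1 to compound 2 (1.42 log units; beyond the scatter), a large step. Compound 3 `COc1ccc(NC(=[Se])Nc2ccc3c(C)cc(=O)oc3c2)cc1` gives 23000 nM, the higher of the two numeric values in the series. Its 4-methoxyphenyl in place of butyl accounts for a 6.1-fold higher number from compound 2 to compound 3 (0.78 log units; beyond the scatter), a modest step.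

Compound 4 `Cc1cc(=O)oc2cc(NC(=[Se])Nc3ccc(C(F)(F)F)cc3)ccc12` carries trifluoromethyl in place of methoxy on an aromatic carbon, para to a large group: trifluoromethyl in place of methoxy on an aromatic carbon. Among the compounds with values here, no measured step changes this substituent. The step to compound 3 is the nearest guide, as it alone places a substituted aromatic ring on the amine nitrogen. A smaller change on that ring is expected to give a smaller step than that modest one, with only a slight lean towards a lower number. The expected step is a 1.5-fold lower number from compound 3 to compound 4 (0.19 log units; within the scatter). For compound 4, the estimate in this assay is 15000 nM, with an expected range of 5000 nM to 45000 nM.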

Compound 4, concentration for 50% growth inhibition: 6000 nM
The estimate for compound 4 lay 2.5-fold (0.40 log units) above the measured number, within the range that was stated.
By their numbers in this assay, from the lowest: compounds 2 and 4 (each within the scatter of the next); then compound 3. At a limit, above all of these: compound 1.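

In this assay, the substituent on an aromatic carbon, para to a large group, is enough on its own to shift the number: a 3.8-fold lower number from compound 3 to compound 4 (0.58 log units; beyond the scatter). An aromatic ring on the amine nitrogen therefore does not by itself fix the higher number of compound 3, since compound 4 gives 6000 nM and compound 2 gives 3800 nM, two values within the scatter of each other. Nothing in the data shown accounts for the size of this step.

Among the compounds shown, this place carries only methoxy and trifluoromethyl, so the effect of chlorine, a nitrile or an amine there remains open. Also open, from the compounds shown here alone, is how a longer chain than butyl on the amine nitrogen would compare with compound 2 and compound 4.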